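The compounds below may be only part of what the source reports. "The series", "measured", "known", "first", "only" and "open" are said of these compounds alone.

The measured compounds so far:

compound 1, `O=c1cc(-n2cc(COc3ccc(F)cc3)nn2)c2ccccc2o1`, 5840 nM
compound 2, `O=[N+]([O-])c1cnc2ccc(Br)cc2c1-n1cc(CSc2ccccc2)nn1`, 22700 nM
compound 3, `O=[N+]([O-])c1cnc2ccc(Br)cc2c1-n1cc(COc2ccccc2)nn1`, 7690 nM

In a functional assay on MCF7 cells (Homo sapiens) for antiproliferative activity, read by MTT assay, with a stated time of 48 h (on this read-out higher numbers stand for weaker inhibition and lower numbers for stronger inhibition), compound 3 gives 7690 nM, the second highest of the three numbers. Compound 1, with 5840 nM, lies nearest to it, a gap within the scatter, so no order between the two can be claimed. Within the data shown here, compound 2 lies furthest, and the single step between compounds that differ in one place, a 3.0-fold lower number from compound 2 to compound 3 (0.47 log units; beyond the scatter), concerns the atom that links the chain carbon to the phenyl ring, not a substituent on that ring.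

Compound 4, `CCOC(=O)c1ccc(OCc2cn(-c3c([N+](=O)[O-])cnc4ccc(Br)cc34)nn2)cc1`, differs from compound 3 by ethoxycarbonyl in place of hydrogen on an aromatic carbon. Among the measured compounds shown here, no measured step changes a substituent on this phenyl ring, so the only step that bears on it at all, a 3.0-fold lower number from compound 2 to compound 3 (0.47 log units; beyond the scatter), does so loosely and in a different part of the molecule. With nothing pointing in either direction, the expected step in this assay from compound 3 to compound 4 is none beyond the scatter. Compound 4 is therefore expected to give about 6500 nM in this assay, within a range from 2500 nM to 17000 nM. This estimate corresponds to an expected step of a 1.2-fold lower number from compound 3 to compound 4 (0.07 log units; within the scatter).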

Compound 4, half-maximal inhibitory concentration: 13900 nM
For compound 4 the middle estimate is 2.1-fold (0.33 log units) below the measured one; the range from low to high includes it.
By their numbers in this assay, from the lowest: compounds 1, 3, 4 and 2 (each within the scatter of the next, the first and the last beyond it).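

In this assay, among these compounds, the first measured change on this phenyl ring gives a 1.8-fold higher number from compound 3 to compound 4 (0.26 log units; within the scatter) and so does not separate compound 4 from compound 3, even though ethoxycarbonyl brings 5 heavy atoms to an aromatic carbon para to a large group. The earlier compounds shown here spoke only to the atom that links the chain carbon to the ring, where the step was a 3.0-fold lower number from compound 2 to compound 3 (0.47 log units; beyond the scatter) and lay beyond the scatter, whereas this single example shows that a substituent of this size on the ring need not produce a step of that kind. No measurement shown here bears on the reason for this result.

Going by these compounds, whether a carboxylic acid, an amine or a longer chain in the same place would also stay within the scatter remains open, since one substituent cannot define what this position accepts. Also open, on these data alone, is whether ethoxycarbonyl would give a comparable step in compound 2, with its phenylsulfanyl group, or on the core of compound 1.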